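The source may hold more compounds than are shown below. What is called first, only, known or untested is meant among the compounds shown, and "the series" means these compounds.

Working notes on the series. In a functional assay for inhibition, with Homo sapiens as the target (on this read-out higher numbers stand for weaker inhibition and lower numbers for stronger inhibition), compound 1 (`O=C(NC[C@H](NS(=O)(=O)c1ccccc1)C(=O)O)c1cc2cc(OCC3CCNCC3)ccc2[nH]1`) gives 13 nM. Compound 2 (`O=C(NC[C@H](NS(=O)(=O)c1ccccc1)C(=O)O)c1cc2cc(OCCC3CCNCC3)ccc2[nH]1`) gives 8 nM, and compound 3 (`O=C(NC[C@H](NS(=O)(=O)c1ccccc1)C(=O)O)c1cc2ccc(OCC3CCNCC3)cc2[nH]1`) gives 15 nM. Compound 1 therefore stands within the scatter of both other measured compounds, and no ranking of it against them can be drawn from these numbers.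

Compound 4 (`O=C(NC[C@H](NS(=O)(=O)c1ccccc1)C(=O)O)c1cc2cc(OCC3CCNCC3)ccc2n1Cc1ccccc1`) departs from compound 1 at one place, with benzyl in place of hydrogen on an aromatic nitrogen. Going by the values given here, the only measured step, a 1.6-fold lower number from compound 1 to compound 2 (0.21 log units; within the scatter), lies within the scatter and concerns the chain on the oxygen, not this nitrogen. It therefore gives no direct guide to the size of the new step, and neither does the value of compound 3. As far as these compounds go, the series holds no measured change at the aromatic nitrogen, so the direction in this assay remains open. A modest move towards a higher number is assumed as a cautious working expectation, with a range that stays wide on both sides. The expected step is a 2.3-fold higher number from compound 1 to compound 4 (0.36 log units; beyond the scatter). For compound 4 the estimated value is 30 nM, with an expected range from 7 nM to 130 nM.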

Compound 4, half-maximal inhibitory concentration: 150 nM
Compound 4: the middle estimate sits 5.0-fold (0.70 log units) below what was measured, outside the stated range (above it).
By their numbers in this assay, from the lowest: compounds 2, 1 and 3 (each within the scatter of the next); then compound 4.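

In this assay, the aromatic nitrogen of the shared core proves to be a position where a single change moves the read-out well beyond the scatter: benzyl in place of hydrogen gives a 12-fold higher number from compound 1 to compound 4 (1.06 log units; beyond the scatter). Going by these compounds alone, the earlier compounds could not show this, as the only step among them, a 1.6-fold lower number from compound 1 to compound 2 (0.21 log units; within the scatter), concerns the chain on the oxygen and lies within the scatter, so the series had looked flat up to this point. The change does two things at once, removing the hydrogen from the nitrogen and adding a six-membered aromatic ring of carbon on a one-carbon link, and no measurement at hand explains the size of the step.

As far as these compounds go, it remains open whether methyl on this nitrogen would give a step of similar size, which would separate the loss of the hydrogen from the presence of the benzyl ring. Also open, from the compounds shown here alone, are how 2-phenylethyl or a benzyl carrying a carboxylic acid or an amine on its ring would read here, and whether the step would hold on the longer chain of compound 2.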